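Thiosemicarbazone amine swap: cyclohexylamino to dimethylamino

The source may hold more compounds than are shown below. What is called first, only, known or untested is meant among the compounds shown, and "the series" means these compounds.

Compound 1 `CNC(=S)N/N=C/c1cccc2ccccc12` gives 2000 nM in a functional assay on B16 cells (Mus musculus), read by spectrophotometry, with a stated time of 3 days; on this read-out higher numbers stand for weaker inhibition and lower numbers for stronger inhibition.
Compound 2 `S=C(N/N=C/c1cccc2ccccc12)NC1CCCCC1` gives 290 nM in this assay.

Going by the values given here, of the two measured compounds, compound 2 has the lower number, and its only neighbour is compound 1, from which it is separated by a 6.9-fold lower number from compound 1 to compound 2 (0.84 log units; beyond the scatter). Among the compounds with values here, that step exchanged a methyl for a cyclohexyl on the amide-type nitrogen and is the only measured step available.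

Compound 3 `CN(C)C(=S)N/N=C/c1cccc2ccccc12` differs from compound 2 in that (dimethylamino in place of cyclohexylamino on a thiocarbonyl carbon). Within the data shown here, this change removes the cyclohexyl that, in the step from compound 1 to compound 2, went with a lower number, and it also removes the single hydrogen-bond donor of that group, a change no measured pair addresses. Taken together, the number is expected to rise, back toward or beyond that of compound 1, with a step of roughly a 10-fold higher number from compound 2 to compound 3 (1.01 log units; beyond the scatter) in this assay. Compound 3 is therefore estimated at 3000 nM, within a range from 800 nM to 15000 nM.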

Compound 3, half-maximal inhibitory concentration: 280 nM
For compound 3 the middle estimate is 11-fold (1.03 log units) above the measured one; measured number outside the range, below it.
By their numbers in this assay, from the lowest: compounds 3 and 2 (each within the scatter of the next); then compound 1.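

In this assay, dimethylamino in place of cyclohexylamino on the thiocarbonyl carbon gives a 1.0-fold lower number from compound 2 to compound 3 (0.02 log units; within the scatter), so this read-out does not separate the two groups, even though the ring and the hydrogen-bond donor of cyclohexylamino both leave. The other new comparison is smaller in structure but larger in result: methyl in place of hydrogen on the amide-type nitrogen gives a 7.1-fold lower number from compound 1 to compound 3 (0.85 log units; beyond the scatter). Among these three compounds, then, a large ring is not required at this position for the lower numbers, and neither is a hydrogen-bond donor on this nitrogen, while compound 1, which carries methylamino there, stands apart from both others; no measurement is available that explains this.

The compounds shown leave open how groups such as diethylamino, piperidinyl or morpholinyl would behave on the thiocarbonyl carbon, and whether they would fall with compound 2 and compound 3 or with compound 1. They also leave open what a plain amino group at this position would give, which would show how far the number moves when both methyl groups of dimethylamino are replaced by hydrogen.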